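Trifluorophenyl isomers on the shared core, cytotoxicity notes

The source may hold more compounds than are shown below. What is called first, only, known or untested is meant among the compounds shown, and "the series" means these compounds.

Measured in a functional assay on NALM-6 cells (Homo sapiens) for cytotoxicity, with a stated time of 72 h; on this read-out higher numbers stand for an effect only at larger amounts of compound and lower numbers for an effect already at smaller amounts:
- compound 1 `C=C[C@@](C)(/C=C/c1ccc(Nc2ccc(F)cc2)cc1)CCC=C(C)C` gives > 43400 nM as a limit
- compound 2 `C=C[C@@](C)(/C=C/c1ccc(Nc2ccc(F)c(F)c2)cc1)CCC=C(C)C` gives > 43400 nM as a limit
- compound 3 `C=C[C@@](C)(/C=C/c1ccc(Nc2cc(F)c(F)cc2F)cc1)CCC=C(C)C` gives > 43400 nM as a limit

Among the measured compounds shown here, no compound has a number yet. The three values together show the limit of > 43400 nM in this assay, at which 3 of the 3 values shown sit, and nothing finer. Compound 3 therefore has no exact place on the scale, and its value of > 43400 nM is a limit only.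

The next compound is compound 4 `C=C[C@@](C)(/C=C/c1ccc(Nc2c(F)cc(F)cc2F)cc1)CCC=C(C)C` with the same atoms as compound 3, joined differently. The change is 2,4,6-trifluorophenyl in place of 2,4,5-trifluorophenyl on a nitrogen on an aromatic ring and the counts on both sides match.

Bearing on this change are a step that the two limits leave unreadable from compound 1 to compound 2 and a step that the two limits leave unreadable from compound 2 to compound 3 and also a step that the two limits leave unreadable from compound 1 to compound 3 and none of these gives a size. No step beyond the scatter is therefore expected in this assay and a report of a limit alone is the likeliest outcome.

The expected change is a step that the limit leaves unreadable from compound 3 to compound 4 and this is an estimate only. For compound 4 the estimated value is 50000 nM with an expected range from 30000 nM to 90000 nM in the same read-out.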

Compound 4, half-maximal effective concentration: > 43400 nM
Compound 4: a limit, no number; the forecaster's own chance of this, stated with the estimate: 85%; the middle value is on the limit's open side.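

No step can be read between compound 4 and compound 1, compound 2 or compound 3 in this assay, as all of them stand at the same limit: the limit of > 43400 nM in this assay, at which 4 of the 4 values shown sit.

The compounds shown leave open how these fluorinated phenyl groups on the shared core compare with one another in this assay, and whether any of these compounds has an exact value there.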